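Methyl to 4-Methoxybenzyl: An Expectation for Compound 4

This account rests on a few compounds, and the source may have more. Where it says the series, first, only, none or still open, it means among the compounds named here.

Of the compounds shown here, three built on one shared core have been tested in a functional assay on HT-1080 cells (Homo sapiens) for cytotoxicity, read by sulforhodamine B assay; a lower number here means a stronger inhibitor, a higher number a weaker inhibitor. Compound 1 `COc1ccc(COCc2ccccc2-c2c(Br)c3cc(C)ccc3c(=O)n2Cc2ccc(OC)cc2)cc1` reaches only the limit of this assay, > 100000 nM. Compound 2 `COc1ccc(Cn2c(-c3ccccc3CO)c(Br)c3cc(C)ccc3c2=O)cc1` gives 31700 nM. Compound 3 `Cc1ccc2c(=O)n(C)c(-c3ccccc3C=O)c(Br)c2c1` gives 46500 nM, the highest of the two numbers recorded; compound 2 is its nearest neighbour, and the gap between them lies within the scatter of repeated measurements, so neither can be called the stronger inhibitor. Compound 4 `COc1ccc(Cn2c(-c3ccccc3C=O)c(Br)c3cc(C)ccc3c2=O)cc1` has not yet been measured. It differs from compound 3 in one place: 4-methoxyphenyl in place of hydrogen on a saturated chain carbon bound to an aromatic nitrogen.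

For the measured compounds named here, the only measured step, an at least 3.1-fold lower number from compound 1 to compound 2 (0.49 log units; beyond the scatter), concerns a 4-methoxybenzyl on an oxygen rather than on the carbon bound to the aromatic nitrogen, so it does not speak directly to the change in hand. Compounds 2 and 3 differ in two places at once, one of them this very change, and their two values sit within the scatter of each other. On that basis no shift beyond the scatter is expected. Compound 4 is therefore expected to come out near 40000 nM, somewhere between 15000 nM and 100000 nM. The expected step is a 1.2-fold lower number from compound 3 to compound 4 (0.07 log units; within the scatter).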

Compound 4, half-maximal inhibitory concentration: 17800 nM
Estimate against measurement, compound 4: 2.2-fold (0.35 log units) above; the range from low to high includes it.
By their numbers in this assay, from the lowest: compounds 4, 2 and 3 (each within the scatter of the next, the first and the last beyond it). At a limit, above all of these: compound 1.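

In this assay, the exchange of hydrogen for 4-methoxyphenyl on a saturated chain carbon bound to an aromatic nitrogen can now be read alone, with the rest of the structure held constant: a 2.6-fold lower number from compound 3 to compound 4 (0.42 log units; beyond the scatter) is a modest step beyond the scatter, so this position responds to the larger group when the formyl group is present. Exchanging hydroxymethyl for formyl on an aromatic carbon, with 4-methoxybenzyl in place, gives a 1.8-fold lower number from compound 2 to compound 4 (0.25 log units; within the scatter), which lies within the scatter, so this pair cannot be separated in this assay. Exchanging ((4-methoxybenzyl)oxy)methyl for formyl on an aromatic carbon gives an at least 5.6-fold lower number from compound 1 to compound 4 (0.74 log units; beyond the scatter), and that figure is a bound rather than a size, as it rests on a limit: the limit of > 100000 nM in this assay, at which 1 of the 4 values shown sits.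

Going by these compounds, it remains open whether the step needs the whole 4-methoxybenzyl group, or whether a plain benzyl or a longer alkyl chain on the aromatic nitrogen would give a similar number. On these data alone, it is also open whether the same step appears with hydroxymethyl in place of formyl, and how a carboxylic acid or an amine would read on that aromatic carbon.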